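This account rests on a few compounds, and the source may have more. Where it says the series, first, only, none or still open, it means among the compounds named here.

For the measured compounds named here, in an ADME assay on microsomes from liver (Homo sapiens) for metabolic stability (on this read-out higher numbers stand for a longer-lived compound and lower numbers for a shorter-lived compound), compound 2 `CCc1cccc2ccc(-c3ccc(C(/C=C4\OC(=O)NC4=O)(CC)CC)c(=O)[nH]3)cc12` gives 0.178 h, the only actual number so far in this small set. Compound 1 `CC(C)C(/C=C1\NC(=O)NC1=O)c1ccc(-c2ccc3cccc(F)c3c2)[nH]c1=O` reads > 3 h, which is a limit of the assay. Compound 3 `Cc1cc(C(/C=C2\OC(=O)NC2=O)C(C)C)c(=O)[nH]c1-c1ccc2cccc(F)c2c1` reads > 3 h, again a limit. Compound 4 `CCC(/C=C1\OC(=O)NC1=O)(CC)c1ccc(-c2ccc3cccc(F)c3c2)[nH]c1=O` departs from compound 2 by one change, fluoro in place of ethyl on an aromatic carbon. Going by the values given here, no measured pair isolates this change, so its size remains uncertain. A rise well beyond the scatter is expected in this assay, because compound 3 with fluoro reads the limit > 3 h. The expected move is an 11-fold higher number from compound 2 to compound 4 (1.05 log units; beyond the scatter). Compound 4 is estimated at 2 h, with an expected range of 0.6 h to 6 h.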

Compound 4, half-life: 0.948 h
The estimate for compound 4 lay 2.1-fold (0.32 log units) above the measured number; the measured number falls inside the stated range.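

In this assay, for the compounds shown here, fluoro in place of ethyl on an aromatic carbon now has a measured size, the first step that can be read as a number: a 5.3-fold higher number from compound 2 to compound 4 (0.73 log units; beyond the scatter). Going by these compounds alone, the change is seen only on the core shared by compound 2 and compound 4. With fluoro at this place, compound 4 still falls short of the limit of the assay: the limit of > 3 h in this assay, at which 2 of the 4 values shown sit.

As far as these compounds go, what a methoxy group or a chlorine on this aromatic carbon would give stays open. Also open, from the compounds shown here alone, is how much of the step belongs to the loss of ethyl and how much to the entry of fluoro.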